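The source may hold more compounds than are shown below. What is called first, only, known or untested is meant among the compounds shown, and "the series" means these compounds.

Compound 1, `COc1cc2c(cc1OC)C(CC(=O)Nc1ccc(Br)cc1)CC2`, in a functional assay on the whole organism (strain Wistar) for inhibition, with Rattus norvegicus as the target, read by paw edema, with a stated time of 2 h, at a dose of 100 mg/kg (on this read-out higher numbers stand for more inhibition at the one dose given (going by the name of the read-out) and lower numbers for less inhibition), gives 40%.
Compound 2, `COc1cc2c(cc1OC)C(CC(=O)Nc1ccccc1C)CC2`, in this assay gives 18%.
Compound 3, `COc1cc2c(cc1OC)C(CC(=O)Nc1ccc([N+](=O)[O-])cc1)CC2`, in this assay gives 36%.

Compound 2 stands lowest of these three in this assay, with both compound 3 and compound 1 above it by more than the usual scatter. The next compound, compound 4, `COc1cc2c(cc1OC)C(CC(=O)Nc1ccncc1)CC2`, differs from compound 2 only in the group on the amide-type nitrogen: pyridin-4-yl in place of 2-methylphenyl on an amide-type nitrogen. Going by the values given here, one measured step touches this same nitrogen, a number 22 percentage points lower from compound 1 to compound 2 (beyond the scatter), in which 2-methylphenyl had replaced 4-bromophenyl. The other step, a number 4 percentage points lower from compound 1 to compound 3 (within the scatter), exchanged bromo for nitro on an aromatic carbon and stayed within the scatter. Among the compounds with values here, no measured compound carries pyridin-4-yl, so the new group itself has no precedent here. Compound 1 gave 40% and compound 3 gave 36%, both beyond the scatter above compound 2. On that basis the step to compound 4 is expected to go modestly upward, a number 12 percentage points higher from compound 2 to compound 4 (beyond the scatter). Compound 4 is therefore estimated at 30%, with a range from 12% to 48%.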

Compound 4, a percentage reported as inhibition, in the whole organism at one dose (the size of the read-out at that dose, not a potency): 44%
Compound 4: middle estimate off by 14 percentage points, on the low side, within the range that was stated.
By their numbers in this assay, from the lowest: compound 2; then compounds 3, 1 and 4 (each within the scatter of the next).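

In this assay, the group on the amide-type nitrogen need not be a ring of carbon only: pyridin-4-yl, a six-membered aromatic ring with 1 hetero atom, gives a number 26 percentage points higher from compound 2 to compound 4 (beyond the scatter). Set against 4-bromophenyl at the same nitrogen, the change reads a number 4 percentage points higher from compound 1 to compound 4 (within the scatter), so these two groups cannot be told apart on this read-out, while 2-methylphenyl falls short of both. No measurement here accounts for these differences.

As far as these compounds go, it stays open whether the rise from 2-methylphenyl goes with the ring nitrogen or with the loss of the methyl, as the change alters both at once. Plain phenyl and pyridin-3-yl at this nitrogen would help separate the two, and piperidinyl would test whether an aromatic ring is needed at all.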